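Working notes: from compound 1 to compound 4

This account rests on a few compounds, and the source may have more. Where it says the series, first, only, none or still open, it means among the compounds named here.

In a functional assay on PC-3 cells (Homo sapiens) for cytotoxicity, read by MTT assay, with a stated time of 72 h (a lower number here means a stronger inhibitor, a higher number a weaker inhibitor), compound 1 (`CNC(=O)c1cc(Oc2ccc(C3=NNC(c4ccc(F)cc4Cl)C3)cc2)ccn1`) gives 24300 nM, the highest of three numbers. Compound 2 (`CNC(=O)c1cc(Oc2ccc(C3=NNC(c4ccccc4)C3)cc2)ccn1`) gives 4520 nM, and compound 3 (`CNC(=O)c1cc(Oc2ccc(C3=NNC(c4ccc(F)cc4)C3)cc2)ccn1`) gives 6770 nM. Compound 4 (`CNC(=O)c1cc(Oc2ccc(C3=NNC(c4ccc(Br)cc4)C3)cc2)ccn1`) is unmeasured, with 4-bromophenyl in place of 2-chloro-4-fluorophenyl on a saturated ring carbon.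

Two steps beyond the scatter bear on this change, a 5.4-fold lower number from compound 1 to compound 2 (0.73 log units; beyond the scatter) and a 3.6-fold lower number from compound 1 to compound 3 (0.56 log units; beyond the scatter), and both remove the chloro. Adding fluoro gave a 1.5-fold higher number from compound 2 to compound 3 (0.18 log units; within the scatter), within the scatter. Among the measured compounds shown here, no bromo compound has been measured, so that contribution remains open.

A modest drop is therefore expected, estimated as a 4.1-fold lower number from compound 1 to compound 4 (0.61 log units; beyond the scatter). The estimate for compound 4 is 6000 nM, with an expected range of 2500 nM to 14000 nM.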

Compound 4, half-maximal inhibitory concentration: > 50000 nM
Compound 4 was reported as a limit (the forecaster's own chance of this, stated with the estimate: 5%); at least 8.3-fold (0.92 log units) between middle value and limit.
By their numbers in this assay, from the lowest: compounds 2 and 3 (each within the scatter of the next); then compound 1. At a limit, above all of these: compound 4.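

In this assay compound 4 gives > 50000 nM, a limit of the assay and not a number. The halogen on this phenyl now matters: fluoro in place of hydrogen stayed within the scatter, but bromo gives an at least 7.3-fold higher number from compound 3 to compound 4 (0.86 log units; beyond the scatter) and an at least 11-fold higher number from compound 2 to compound 4 (1.04 log units; beyond the scatter). Among the compounds shown here, removing the chloro lowered the number in the earlier steps, yet the full change to 4-bromophenyl gives an at least 2.0-fold higher number from compound 1 to compound 4 (0.31 log units; beyond the scatter), so that loss alone does not set the outcome.

From the compounds shown here alone, how far compound 4 lies past its limit stays open: the limit of > 50000 nM in this assay, at which 1 of the 4 values shown sits. Going by these compounds, whether a methoxy group or an amine in place of the bromo would stay close to compound 2 also remains open.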